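A Carbamate Takes the Place of a Hydantoin

The compounds below may be only part of what the source reports. "The series", "measured", "known", "first", "only" and "open" are said of these compounds alone.

In a physicochemical assay for lipophilicity, read by HPLC, measured as octanol-water partition (on this read-out higher numbers stand for higher lipophilicity and lower numbers for lower lipophilicity), compound 3 `O=C1CNC(=O)N1C[C@H]1CN(c2ccc(-n3cc(-c4ccccn4)cn3)c(F)c2)C(=O)O1` gives 1.25, the lowest of the three measured numbers. Compound 1 `CN(CCC#N)C[C@H]1CN(c2ccc(-n3cc(-c4ccccn4)cn3)c(F)c2)C(=O)O1` gives 1.9 and compound 2 `COC(=O)CC1CCN(C[C@H]2CN(c3ccc(-n4cc(-c5ccccn5)cn4)c(F)c3)C(=O)O2)CC1` gives 1.78. The two steps that lead into compound 3 both lowered the number: a number 0.65 log units lower from compound 1 to compound 3 (beyond the scatter) and a number 0.53 log units lower from compound 2 to compound 3 (beyond the scatter). Compound 4 `COC(=O)NC[C@H]1CN(c2ccc(-n3cc(-c4ccccn4)cn3)c(F)c2)C(=O)O1` differs from compound 3 at the same place: (methoxycarbonyl)amino in place of 2,5-dioxoimidazolidin-1-yl on a saturated chain carbon bound to a saturated ring carbon. Within the data shown here, no measured step shows the (methoxycarbonyl)amino group itself, so the expectation rests on the two steps in which the 2,5-dioxoimidazolidin-1-yl group entered and the number fell. With that group leaving, a modest rise of a number 0.35 log units higher from compound 3 to compound 4 (beyond the scatter) in this assay is expected. Compound 4 is estimated at 1.6, within a range of 1.2 to 2.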

Compound 4, partition coefficient: 2.03
For compound 4 the middle estimate is 0.43 log units below the measured one; the whole stated range lies below it.
By their numbers in this assay, from the lowest: compound 3; then compounds 2, 1 and 4 (each within the scatter of the next).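

In this assay, exchanging the 2,5-dioxoimidazolidin-1-yl ring for the open-chain (methoxycarbonyl)amino group gives a number 0.78 log units higher from compound 3 to compound 4 (beyond the scatter), although both groups carry the same count of hydrogen-bond donors and acceptors. Compound 3 now stands apart from all three others at this position, while the remaining steps give a number 0.25 log units higher from compound 2 to compound 4 (within the scatter) and a number 0.13 log units higher from compound 1 to compound 4 (within the scatter). Nothing available here explains the size of the change. Still open, going by these compounds, is whether a carboxylic acid or a primary amine on a saturated chain carbon bound to a saturated ring carbon would give a number near compound 3 or near the other three.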